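Urea to chloroacetamide on the tert-butylphenyl series

This account rests on a few compounds, and the source may have more. Where it says the series, first, only, none or still open, it means among the compounds named here.

Measured compounds:
- compound 1, `CC(C)(C)c1ccc(NC(=O)NCCCCl)cc1`: 28000 nM
- compound 2, `CCCCCc1cccc(NC(=O)NCCCCl)c1`: 28000 nM

Both measured compounds carry the same (3-chloropropyl)urea arm on an aniline-type core. In a functional assay on HT-29 cells (Homo sapiens) for antiproliferative activity, with a stated time of 48 h (a higher number here means a weaker inhibitor, a lower number a stronger inhibitor), compound 1 gives 28000 nM. In this assay compound 2 gives 28000 nM, which is level with compound 1 at the digits shown and lies within the scatter, so nothing separates the two as regards their values.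

Compound 3, `CC(C)(C)c1ccc(NC(=O)CCl)cc1`, has not yet been measured. Its structure differs from compound 1 in one place: chloromethyl in place of (3-chloropropyl)amino on a carbonyl carbon. For the measured compounds named here, no measured pair shows this change, so its size rests on expectation alone. The expected direction for compound 3 is toward a lower number, hence a stronger inhibitor, with a step of a 3.5-fold lower number from compound 1 to compound 3 (0.54 log units; beyond the scatter) expected in this assay. For compound 3 the estimate in this assay is 8000 nM, with a range from 1500 nM to 40000 nM.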

Compound 3, half-maximal inhibitory concentration: 15000 nM
The estimate for compound 3 lay 1.9-fold (0.27 log units) below the measured number; the range from low to high includes it.
By their numbers in this assay, from the lowest: compounds 3, 1 and 2 (each within the scatter of the next).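

In this assay, chloromethyl in place of (3-chloropropyl)amino on a carbonyl carbon gives a 1.9-fold lower number from compound 1 to compound 3 (0.27 log units; within the scatter), so this first reading at the position does not separate the two compounds. The arm can therefore lose the (3-chloropropyl)amino group, together with its hydrogen-bond donor and three of its heavy atoms on balance, without a difference that can be told from the scatter in this read-out. Nothing at hand explains this result.

The compounds shown leave open what a plain methyl group or a longer chloroalkyl chain on the same carbonyl carbon would give, and so whether the chlorine matters at this position. They also leave open whether chloromethyl reads the same way on the core of compound 2.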